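This account rests on a few compounds, and the source may have more. Where it says the series, first, only, none or still open, it means among the compounds named here.

Compound 1 `O=C(Nc1cccc(-n2cc(-c3ccncc3)c(-c3ccc(Cl)c(O)c3)n2)c1)Nc1ccc(Cl)c(Cl)c1`: in a functional assay on M14 cells (Homo sapiens) for inhibition, read by sulforhodamine B assay, with a stated time of 48 h (a higher number here means that more compound is tolerated, a lower number that less compound is tolerated), compound 1 gives > 32500 nM, a limit of the assay.
Compound 2 `COc1cc(-c2nn(-c3cccc(NC(=O)c4cccc(C(F)(F)F)c4)c3)cc2-c2ccncc2)ccc1Cl`: compound 2 gives > 50000 nM, also a limit.
Compound 3 `O=C(Nc1cccc(-n2cc(-c3ccncc3)c(-c3ccc(Cl)c(O)c3)n2)c1)Nc1cc(C(F)(F)F)cc(C(F)(F)F)c1`: compound 3 gives 6060 nM.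

Compound 2 stands at a limit of this assay (the limit of > 50000 nM in this assay, at which 1 of the 3 values shown sits), so no number is known for it; only compound 3 has a measured value. Compound 4 `COc1cc(-c2nn(-c3cccc(NC(=O)c4ccccc4)c3)cc2-c2ccncc2)ccc1Cl` differs from compound 2 in one place: hydrogen in place of trifluoromethyl on an aromatic carbon. No measured step connects any pair of these compounds, so the size of this change cannot be read from the data. He expects the step of a number no higher from compound 2 to compound 4 (the limit leaves the size open) to be none beyond the scatter. Compound 2 sits at a limit and offers no number to move from. Compound 4 is therefore estimated at 50000 nM, within 20000 nM to 100000 nM, and is expected to be reported again only as a limit.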

Compound 4, concentration lethal to 50% of the cells: > 100000 nM
Compound 4 was reported as a limit (the forecaster's own chance of this, stated with the estimate: 70%); middle value at least 2.0-fold (0.30 log units) from the limit.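

Within the data shown here, compound 2 and compound 4 are both reported only as limits, so no step between them can be read. The compounds shown leave open whether hydrogen in place of trifluoromethyl on an aromatic carbon changes the lethal concentration at all.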